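The compounds below may be only part of what the source reports. "The series", "measured", "known", "first", "only" and "open" are said of these compounds alone.

In a functional assay on HEK293 cells for antagonist activity at thromboxane A2 receptor (Homo sapiens), read by fluorescence and calcium flux (on this read-out lower numbers stand for stronger inhibition and higher numbers for weaker inhibition), compound 1 `Cc1cccc(Oc2ccc(C#N)cc2S(=O)(=O)NC(=O)NC(C)C)c1` gives 1690 nM and compound 2 `CCCCCNC(=O)NS(=O)(=O)c1cc(C#N)ccc1Oc1cccc(C)c1` gives 680 nM. The change between them is pentyl in place of isopropyl on an amide-type nitrogen, and its step is a 2.5-fold lower number from compound 1 to compound 2 (0.40 log units; beyond the scatter). Compound 3 `CC(C)NC(=O)NS(=O)(=O)c1cc(C#N)ccc1Nc1ccc(F)cc1` has a different core: the difference from compound 1 is (4-fluorophenyl)amino in place of 3-methylphenoxy on an aromatic carbon, and the step is a 4.6-fold higher number from compound 1 to compound 3 (0.67 log units; beyond the scatter), so that in this assay compound 3 gives 7830 nM, the highest number among the three measured compounds. Compound 4 `CCCCCNC(=O)NS(=O)(=O)c1cc(C#N)ccc1Nc1ccc(F)cc1` has not yet been measured; it differs from compound 3 by pentyl in place of isopropyl on an amide-type nitrogen, the same change as from compound 1 to compound 2, at a place described in identical words. Resting on that earlier step alone, compound 4 is expected to show a step of a 2.5-fold lower number from compound 3 to compound 4 (0.40 log units; beyond the scatter) in this assay. Compound 4 is accordingly estimated at 3100 nM, with a likely range from 1500 nM to 7000 nM.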

Compound 4, half-maximal inhibitory concentration: 6450 nM
Compound 4: the middle estimate sits 2.1-fold (0.32 log units) below what was measured, within the range that was stated.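

In this assay, pentyl in place of isopropyl gives a 1.2-fold lower number from compound 3 to compound 4 (0.08 log units; within the scatter), and the two steps for this change agree: the same change on two cores in this assay, a 2.5-fold lower number (0.40 log units; beyond the scatter) from compound 1 to compound 2 and a 1.2-fold lower number (0.08 log units; within the scatter) from compound 3 to compound 4, 2.0-fold (0.31 log units) apart, within the scatter of two such steps. (4-Fluorophenyl)amino in place of 3-methylphenoxy, read with pentyl on the amide-type nitrogen, gives a 9.5-fold higher number from compound 2 to compound 4 (0.98 log units; beyond the scatter), and this step also agrees with its earlier counterpart: the same change on two cores in this assay, a 4.6-fold higher number (0.67 log units; beyond the scatter) from compound 1 to compound 3 and a 9.5-fold higher number (0.98 log units; beyond the scatter) from compound 2 to compound 4, 2.0-fold (0.31 log units) apart, within the scatter of two such steps. Within the data shown here, each change therefore carried between these two cores within the scatter, but with only two steps for each, this does not show that either change would carry to any other core.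

The compounds shown leave open how a hexyl chain or a chain ending in a carboxylic acid on the amide-type nitrogen would read on either core.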